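A few compounds are considered here, and "the series" means these few. Any claim that something is new, unique, unknown or untested is made for them only; others in the source may bear on it.

Measured compounds: compound 1 `CCC(CC)N1CCN(c2nc3c(c(Nc4ccc(C(F)(F)F)cc4)n2)CCN(c2ncccc2C(F)(F)F)CC3)CC1` gives 185 nM; compound 2 `CC(C)(C)OC(=O)N1CCCC(Nc2nc3c(c(Nc4ccc(C(F)(F)F)cc4)n2)CCN(c2ncccc2C(F)(F)F)CC3)C1` gives 239 nM.

Both values come from a functional assay on HEK293 cells for antagonist activity at transient receptor potential cation channel subfamily V member 1 (Rattus norvegicus), read by FLIPR and calcium flux (on this read-out lower numbers stand for stronger inhibition and higher numbers for weaker inhibition), and in this assay compound 1 shows the lower of the two numbers. That difference from compound 2 is small and lies within the usual scatter of repeated measurements, so the two compounds cannot be told apart on these data alone; neither counts as more potent than the other.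

The next compound, compound 3 `FC(F)(F)c1ccc(Nc2nc(N3CCN(C4CCC4)CC3)nc3c2CCN(c2ncccc2C(F)(F)F)CC3)cc1`, shares the core of compound 1 and differs from it in one place: cyclobutyl in place of pentan-3-yl on an amine nitrogen in a ring. Cyclobutyl takes the place of pentan-3-yl on an amine nitrogen in a ring. For the measured compounds named here, no pair of measured compounds shows this or any other single change, so there is no measured step to lean on; the expectation rests only on the fact that both measured compounds sit close together. The step from compound 1 to compound 3 is expected to be no larger than the scatter, in either direction, as a 1.1-fold higher number from compound 1 to compound 3 (0.03 log units; within the scatter). Compound 3 is therefore estimated at 200 nM in this assay, with a range from 70 nM to 600 nM.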

Compound 3, half-maximal inhibitory concentration: 161 nM
Compound 3: the middle estimate sits 1.2-fold (0.09 log units) above what was measured; low and high end bracket the measured number.
By their numbers in this assay, from the lowest: compounds 3, 1 and 2 (each within the scatter of the next).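

In this assay, for the compounds shown here, the swap on this amine nitrogen gives the first single-place comparison: a 1.1-fold lower number from compound 1 to compound 3 (0.06 log units; within the scatter). The two compounds therefore cannot be told apart on this read-out, even though pentan-3-yl has no ring and 5 heavy atoms, while cyclobutyl has a four-membered carbon ring and 4 heavy atoms. At this position of the piperazine, as the name 4-cyclobutylpiperazin-1-yl prints it, these two all-carbon groups are interchangeable as far as this measurement can show, although no measured data indicate why they read alike.

From the compounds shown here alone, this single pair says nothing about groups of a different kind on the same nitrogen, such as a methyl, an acetyl, an oxetane ring or a chain ending in a carboxylic acid, so the range of groups that would leave the number in place remains open. It also leaves open whether a larger all-carbon ring, such as cyclohexyl, would read the same as cyclobutyl and pentan-3-yl.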